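The source may report more compounds than this note shows. Statements on the series, on what has been measured and on what is new or still open speak of the compounds shown alone.

Measured compounds in an assay on HEK293 cells for displacement of a labelled ligand from 5-hydroxytryptamine receptor 7 (Rattus norvegicus); on this read-out lower numbers stand for stronger inhibition and higher numbers for weaker inhibition:
Compound 1 `O=C(CCCCCN1CCN(c2noc3ccccc23)CC1)NC1CCCc2ccccc21` gives 125 nM.
Compound 2 `O=C(CCCCCN1CCN(c2nc3ccccc3o2)CC1)NC1CCCc2ccccc21` gives 820 nM.
Compound 3 `COc1ccc(OC)c(N2CCN(CCCCCC(=O)NC3CCCc4ccccc43)CC2)c1` gives 70.3 nM.

Compound 3 has the lowest number of the three. Its nearest neighbour is compound 1, with a 1.8-fold lower number from compound 1 to compound 3 (0.25 log units; within the scatter), so these two cannot be told apart. Compound 2 stands well away: a 12-fold lower number from compound 2 to compound 3 (1.07 log units; beyond the scatter), and likewise a 6.6-fold higher number from compound 1 to compound 2 (0.82 log units; beyond the scatter).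

The unmeasured compound 4 `COc1cccc(N2CCN(CCCCCC(=O)NC3CCCc4ccccc43)CC2)c1` differs from compound 3 in a single place: hydrogen in place of methoxy on an aromatic carbon. None of the three measured steps touches a methoxy group on its own; each of them swaps the whole group on the amine nitrogen of the ring, with one step large and one within the scatter. So there is no direct precedent for taking one methoxy away while the other stays. What the numbers do show is that the shared core tolerates rather different groups at this nitrogen without collapse of binding, compound 2 being the one exception with a clearly weaker result.

Compound 4 is therefore estimated to lie close to compound 3, with a modest shift toward a weaker number more likely than a gain: a 2.1-fold higher number from compound 3 to compound 4 (0.33 log units; beyond the scatter). The expected value for compound 4 in this assay is 150 nM, within a range from 50 nM to 500 nM.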

Compound 4, inhibition constant: 119 nM
For compound 4 the middle estimate is 1.3-fold (0.10 log units) above the measured one, and the stated range covers the measured number.
By their numbers in this assay, from the lowest: compounds 3, 4 and 1 (each within the scatter of the next); then compound 2.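

In this assay, hydrogen in place of methoxy on the aromatic carbon ortho to a large group and para to a methoxy group gives a 1.7-fold higher number from compound 3 to compound 4 (0.23 log units; within the scatter) and so stays inside the scatter, the first sign that this single methoxy group can be lost without a readable change, which the earlier whole-group swaps could not show. The 3-methoxyphenyl group also keeps a clear margin over 1,3-benzoxazol-2-yl on the amine nitrogen in the ring, with a 6.9-fold lower number from compound 2 to compound 4 (0.84 log units; beyond the scatter) as the step, while a 1.1-fold lower number from compound 1 to compound 4 (0.02 log units; within the scatter) leaves those two compounds indistinguishable, so a single methoxy on the phenyl ring is enough to stay level with compound 1 on this read-out. Nothing available here explains why the methoxy group can go in this way.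

What the remaining methoxy group contributes stays open, as the compounds shown hold no step from 3-methoxyphenyl to a plain phenyl. Equally open, on these data alone, is how a hydroxyl, a fluorine or an ethoxy group would read on the aromatic carbon ortho to a large group, where only methoxy and hydrogen can be compared.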